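The source may hold more compounds than are shown below. What is called first, only, known or untested is meant among the compounds shown, and "the series" means these compounds.

Of the compounds shown here, two have been measured in an assay on membranes from CHO cells for displacement of a labelled ligand from adenosine receptor A1 (Homo sapiens), read by scintillation counting, with a stated time of 60 min, tested at 1 uM; a higher number here means more inhibition at the concentration tested (going by the name of the read-out), a lower number less inhibition. Compound 1 `CCCC(=O)C1=C(C)NC(=O)NC1c1ccoc1` gives 1%. Compound 2 `CC1=C(C(=O)CC(C)C)C(c2ccoc2)NC(=O)N1` gives 23%; this assay shows a number 22 percentage points higher from compound 1 to compound 2 (beyond the scatter), so compound 2 stands highest of the two numbers, with compound 1 the nearest to it and beyond the scatter below it. Compound 3 `CC1=C(C(N)=O)C(c2ccoc2)NC(=O)N1` has not yet been measured. It differs from compound 2 by amino in place of isobutyl on a carbonyl carbon. Among the compounds with values here, no measured step bears directly on this change: the single step from compound 1 to compound 2 concerns a methyl added to the chain that now leaves as a whole, and neither measured compound carries an amino on the carbonyl carbon. The direction of the change is therefore open. Within the data shown here, with only a modest value in compound 2 and a near-zero value in compound 1, the series so far offers little inhibition to lose, and a step back toward the level of compound 1 is as plausible as a gain. Compound 3 is estimated at 8%, range -8% to 30%. This means an expected step of a number 15 percentage points lower from compound 2 to compound 3 (beyond the scatter), with wide uncertainty.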

Compound 3, a percentage reported as inhibition, at one concentration (the size of the read-out at that concentration, not a potency): 1%
Beside the measured number, compound 3's estimate is 7 percentage points above it, and the stated range covers the measured number.
By their numbers in this assay, from the lowest: compounds 1 and 3 (each within the scatter of the next); then compound 2.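

In this assay, amino in place of isobutyl on a carbonyl carbon gives a number 22 percentage points lower from compound 2 to compound 3 (beyond the scatter), so the inhibition seen with isobutylcarbonyl at this place is not kept by carbamoyl. Amino in place of propyl on the same carbon gives no change at the digits printed from compound 1 to compound 3 (within the scatter), which leaves carbamoyl and the propyl-bearing carbonyl indistinguishable here; among these three compounds, only the isobutyl of compound 2 stands beyond the scatter of the other two. No measurement at hand accounts for the position of the isobutyl compound, and the reason for this difference remains unexplained.

Still open, as far as these compounds go, is whether a longer chain or a benzyl group on the carbonyl carbon would raise the number beyond that of compound 2, and whether a dimethylamino group in place of amino would stay level with compound 3 or move toward compound 2. Also open, from the compounds shown here alone, is whether the isobutyl-to-amino step would keep its size with other groups on the shared core, since the reading comes from a single concentration in a single assay.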